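The source may hold more compounds than are shown below. What is called first, only, known or untested is meant among the compounds shown, and "the series" means these compounds.

Measured in a functional assay on HCT-15 cells (Homo sapiens) for cytotoxicity, read by sulforhodamine B assay, with a stated time of 72 h; a lower number here means a stronger inhibitor of growth, a higher number a weaker inhibitor of growth:
compound 1 `O=C(Nc1ccccc1O)C1CCc2ccccc2N1C(=O)c1ccc(Cl)cc1`: 20200 nM
compound 2 `CCCC(=O)N1c2ccccc2CCC1C(=O)Nc1cc(C(F)(F)F)cc(C(F)(F)F)c1`: 21900 nM
compound 3 `CCC(=O)N1c2ccccc2CCC1C(=O)Nc1ccccc1C(F)(F)F`: > 80000 nM

Compound 3 stands at the limit of > 80000 nM in this assay, at which 1 of the 3 values shown sits, so for it this assay gives only a limit and no number. Compound 4 `O=C(Nc1ccccc1C(F)(F)F)C1CCc2ccccc2N1C(=O)c1ccccc1Cl` differs from it by 2-chlorophenyl in place of ethyl on a carbonyl carbon; cut one bond further out, propanoyl becomes (2-chlorophenyl)carbonyl. For the measured compounds named here, no measured pair shows this step. Compound 1 gives 20200 nM and compound 2 gives 21900 nM; the two values lie within the scatter of each other, and neither compound is a measured step from compound 3. The step is expected to move toward stronger growth inhibition, modestly beyond the scatter, an at least 2.0-fold lower number from compound 3 to compound 4 (0.30 log units; that floor lies within the scatter). Compound 4 is estimated at 40000 nM, within 15000 nM to 100000 nM.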

Compound 4, concentration for 50% growth inhibition: 4220 nM
Beside the measured number, compound 4's estimate is 9.5-fold (0.98 log units) above it, and the stated range ends above it.
By their numbers in this assay, from the lowest: compound 4; then compounds 1 and 2 (each within the scatter of the next). At a limit, above all of these: compound 3.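

For the compounds shown here, on the carbonyl carbon whose other neighbour is the amide-type nitrogen in a ring, 2-chlorophenyl in place of ethyl gives the first step that can be read at this position in this assay: an at least 18-fold lower number from compound 3 to compound 4 (1.27 log units; beyond the scatter). This size is a floor and not a measured difference, as compound 3 has only a limit: the limit of > 80000 nM in this assay, at which 1 of the 4 values shown sits.

The compounds shown leave open whether the chlorine or the aromatic ring itself carries this step. They also leave open how an unsubstituted phenyl or a pyridine ring would read on this carbonyl carbon.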